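A few compounds are considered here, and "the series" means these few. Any claim that something is new, unique, unknown or untested is made for them only; others in the source may bear on it.

Measured so far:
- compound 1, `COc1cc(C(=O)N[C@@H]2CCC[C@@H]3CCN(C)C[C@H]32)cc(OC)c1OC`: in a physicochemical assay for acid dissociation, compound 1 gives 8.75
- compound 2, `CN1CC[C@H]2CCC[C@@H](NS(=O)(=O)c3ccccc3)[C@@H]2C1`: in this assay compound 2 gives 8.87

The two values lie within the scatter of each other, so the numbers of compound 1 and compound 2 cannot be told apart. Compound 3, `CN1CC[C@H]2CCC[C@@H](NS(=O)(=O)c3ccccc3)[C@H]2C1`, has not yet been measured in this assay. Against compound 2 the change is the two compounds have the same atoms and bonds and differ only in configuration as drawn: 1 of 3 stereo elements differ; a stereocentre at a saturated ring carbon is drawn S in compound 2 and R in compound 3. Going by the values given here, no measured pair shows what such an inversion does to the acid dissociation constant. With the same atoms and bonds kept, a step no larger than the scatter is expected, in no set direction: the expected step is a number 0.07 log units lower from compound 2 to compound 3 (within the scatter). For compound 3 the estimate is 8.8, within 8.4 to 9.2.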

Compound 3, acid dissociation constant: 9.17
The estimate for compound 3 lay 0.37 log units below the measured number; low and high end bracket the measured number.
By their numbers in this assay, from the lowest: compounds 1, 2 and 3 (each within the scatter of the next, the first and the last beyond it).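

In this assay, going by these compounds alone, the inversion at the saturated ring carbon, drawn S in compound 2 and R in compound 3, gives a number 0.30 log units higher from compound 2 to compound 3 (within the scatter), the first reading of such an inversion. At this stereocentre, the change therefore gives no step beyond the scatter. The comparison rests on one change alone: the fact that compounds 2 and 3 differ only in the configuration as drawn. From the compounds shown here alone, whether the same inversion reads alike with the amide of compound 1, or with a urea in place of the sulfonamide, stays open. So does the outcome of inverting either of the other two stereo elements.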